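A few compounds are considered here, and "the series" means these few. Any claim that something is new, unique, unknown or untested is made for them only; others in the source may bear on it.

Compound 2 `CCc1nc2c(C)cc(C)nc2n1Cc1ccc(-c2ccccc2C2=NS(=O)(=O)c3ccccc3N2)cc1` stands highest of the two numbers in a physicochemical assay for acid dissociation: compound 2 gives 8.7, while compound 1 `CCc1nc2c(C)cc(C)nc2n1Cc1ccc(-c2ccccc2C2=NOS(=O)N2)cc1` gives 5.7. Going by the values given here, the only measured step is a number 3.00 log units higher from compound 1 to compound 2 (beyond the scatter). Compound 3 `CCc1nc2c(C)cc(C)nc2n1Cc1ccc(-c2ccccc2N2N=C(c3ccccc3)N[S+]2[O-])cc1` differs from compound 2 by a group of 12 heavy atoms (7 carbon, 3 nitrogen, 1 oxygen, 1 sulfur; one five-membered non-aromatic ring with 4 hetero atoms, one six-membered aromatic ring of carbon only) in place of a group of 12 heavy atoms (7 carbon, 2 nitrogen, 2 oxygen, 1 sulfur; one six-membered non-aromatic ring with 3 hetero atoms, one six-membered aromatic ring of carbon only), on an aromatic carbon. Among the compounds with values here, no measured step matches this change directly, yet the entering ring is, like that of compound 1, a five-membered non-aromatic ring with 4 hetero atoms, so a sizeable downward step in this assay is expected, partly undoing a number 3.00 log units higher from compound 1 to compound 2 (beyond the scatter). The expected step is a number 2.10 log units lower from compound 2 to compound 3 (beyond the scatter). Compound 3 is therefore estimated at 6.6, within 5.3 to 7.9.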

Compound 3, acid dissociation constant: about 7.1
Compound 3: middle estimate off by 0.50 log units, on the low side; the range from low to high includes it.
By their numbers in this assay, from the lowest: compound 1; then compound 3; then compound 2.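

Compound 3 shows that ring size alone does not settle the reading in this assay at this place on an aromatic carbon: with a five-membered non-aromatic ring with 4 hetero atoms in both compounds, a number 1.40 log units higher from compound 1 to compound 3 (beyond the scatter) still remains. Replacing the six-membered non-aromatic ring with 3 hetero atoms gives a number 1.60 log units lower from compound 2 to compound 3 (beyond the scatter), which places compound 3 between the other two. No available evidence bears on the origin of these steps. The compounds shown leave open how a carboxylic acid or a tetrazole at this place would compare in this assay.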